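A few compounds are considered here, and "the series" means these few. Any claim that something is new, unique, unknown or untested is made for them only; others in the source may bear on it.

Of the compounds shown here, three have so far been measured in a functional assay (brain) for inhibition, with Rattus norvegicus as the target; a higher number here means a weaker inhibitor, a lower number a stronger inhibitor. Compound 1 `Cc1c(C)c2c(c(C)c1O)CCC(C)(C(=O)[N-][N+](C)(C)C)O2` gives 14000 nM, compound 2 `Cc1c(C)c2c(c(C)c1O)CC[C@@](C)(CC(=O)O)O2` gives 17000 nM, and compound 3 `CCCCCCCCCCCCCCCCCCOC1=C(O)[C@@H](C(O)CO)OC1=O` gives 6000 nM. Compound 2 stands at the highest of the three numbers; its value and that of compound 1 lie within the scatter of each other, whereas the value of compound 3 lies beyond the scatter, at the lower number of that pair. Compound 4 `Cc1c(C)c2c(c(C)c1O)CC[C@@](C)(CCN(C)C)O2` has not yet been measured. It differs from compound 2 by (dimethylamino)methyl in place of carboxy on a saturated chain carbon bound to a saturated ring carbon. Going by the values given here, no pair of measured compounds that differ in one place is available, so the size of this step can only be estimated rather than read from a neighbouring case. In this assay compound 4 is expected to give about 10000 nM, with a range from 3000 nM to 40000 nM. The step expected in this assay, a 1.7-fold lower number from compound 2 to compound 4 (0.23 log units; within the scatter), amounts to no change beyond the scatter, though the range leaves room for a shift in either direction.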

Compound 4, half-maximal inhibitory concentration: 1000 nM
Beside the measured number, compound 4's estimate is 10-fold (1.00 log units) above it; the measured number lies below the stated range.
By their numbers in this assay, from the lowest: compound 4; then compound 3; then compounds 1 and 2 (each within the scatter of the next).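

In this assay, going by these compounds alone, carboxymethyl giving way to 2-(dimethylamino)ethyl on the shared core produces a 17-fold lower number from compound 2 to compound 4 (1.23 log units; beyond the scatter), the first step that can be read at this place. It shows that the number depends strongly on the group carried on a saturated chain carbon bound to a saturated ring carbon, and the step is large. The change removes a hydrogen-bond donor, while the count of hydrogen-bond acceptors stays the same, but no measurement given here accounts for the size of the step.

This single pair cannot separate the effect of losing the carboxylic acid from that of gaining the tertiary amine. It also leaves open whether a primary amine, a diethylamino group, a methyl ester or a longer chain at this place would give a number close to that of compound 4.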